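Changing the group on the carbonyl carbon: compound 3 to compound 4

The compounds below may be only part of what the source reports. "The series", "measured", "known", "first", "only" and "open" are said of these compounds alone.

Compound 3 `Cc1ccccc1NC(=O)N1CCC(c2nc(-c3ccc4ccccc4n3)no2)CC1` carries a 2-methylphenyl group on an amide-type nitrogen. In a functional assay on Shh Light II cells (Mus musculus) for inhibition, read by a luciferase reporter (a lower number here means a stronger inhibitor, a higher number a weaker inhibitor), compound 3 gives 440 nM, the lowest of the three numbers measured. Compound 1 `C[C@H]1C[C@H](c2nc(-c3ccc4ccccc4n3)no2)CCN1C(=O)Nc1ccccc1Cl` gives 900 nM in this assay, and compound 2 `Cc1noc(C)c1NC(=O)N1CCC(c2nc(-c3ccc4ccccc4n3)no2)CC1` gives 3000 nM. For the measured compounds named here, the one step measured at this position is a 6.8-fold lower number from compound 2 to compound 3 (0.83 log units; beyond the scatter), which shows that the group on the carbonyl carbon moves the number by a modest amount.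

Compound 4 `COc1ccccc1N(C)C(=O)N1CCC(c2nc(-c3ccc4ccccc4n3)no2)CC1` differs from compound 3 in one place: (2-methoxyphenyl)(methyl)amino in place of (2-methylphenyl)amino on a carbonyl carbon. Going by the values given here, the entering group has no hydrogen-bond donor where the leaving group had one, and no measured pair shows such a change, so the step from compound 2 to compound 3 bears on it only loosely. Given that this position does matter, a weakening of modest size is expected, with wide uncertainty; for compound 4 the expected step is a 3.4-fold higher number from compound 3 to compound 4 (0.53 log units; beyond the scatter). Compound 4 is therefore estimated at 1500 nM, within a range of 500 nM to 6000 nM.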

Compound 4, half-maximal inhibitory concentration: 3100 nM
Compound 4: the middle estimate sits 2.1-fold (0.32 log units) below what was measured, and the stated range covers the measured number.
By their numbers in this assay, from the lowest: compound 3; then compound 1; then compounds 2 and 4 (each within the scatter of the next).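

In this assay, for the compounds shown here, the step from (2-methylphenyl)amino to (2-methoxyphenyl)(methyl)amino on the carbonyl carbon is a 7.0-fold higher number from compound 3 to compound 4 (0.85 log units; beyond the scatter), the first measured change at this position that removes the amide hydrogen. The same entering group set against (3,5-dimethyl-1,2-oxazol-4-yl)amino gives a 1.0-fold higher number from compound 2 to compound 4 (0.01 log units; within the scatter), so a group with the amide hydrogen and a group without it can give numbers within the scatter of each other, and the presence of that hydrogen does not by itself set the number. Nothing measured here accounts for either step.

The shown compounds leave open how much of the change belongs to the methyl on the nitrogen and how much to the methoxy, which (2-methoxyphenyl)amino and (2-methylphenyl)(methyl)amino would separate. Also open, going by these compounds, is how a non-aromatic group such as cyclohexylamino would read on this carbonyl carbon.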